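Amino to fluoro exchange: from compound 2 to compound 4

The source may report more compounds than this note shows. Statements on the series, on what has been measured and on what is new or still open speak of the compounds shown alone.

Compound 2 `Cn1c(=O)[nH]c2c(cnn2-c2ccccc2N)c1=N` gives 0% in an assay on membranes from brain for binding affinity to adenosine receptor A1 (Rattus norvegicus), read by radioligand binding, tested at 20 uM (on this read-out lower numbers stand for less inhibition and higher numbers for more inhibition at the one concentration tested (going by the name of the read-out)), the smallest of the three numbers recorded, though the gap to its nearest neighbour is within the scatter. Compound 1 `Cn1c(=O)[nH]c2c(cnn2-c2ccccc2Br)c1=N` stands nearest with 6%, and compound 3 `Cn1c(=O)[nH]c2c(cnn2-c2cccc(Cl)c2)c1=N` stands furthest with 53%. Among the measured compounds shown here, the only step that joins two measured compounds by a single change, a number 6 percentage points lower from compound 1 to compound 2 (within the scatter), lies within the scatter.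

Compound 4 `Cn1c(=O)[nH]c2c(cnn2-c2ccccc2F)c1=N` is still to be measured in this assay. It differs from compound 2 by fluoro in place of amino on an aromatic carbon. For the measured compounds named here, the step from compound 1 to compound 2 is the one measured step that bears on an exchange on this same aromatic carbon, and it was small; no measured step involves fluoro at all. Compounds 1 and 2, each carrying a single group on this carbon, both gave low numbers, and compound 3 is the only high one among the three. The expectation for compound 4 is therefore a low number, with the estimated step of a number 8 percentage points higher from compound 2 to compound 4 (within the scatter) not expected to run beyond the scatter. Compound 4 is estimated at 8%, with a range from 0% to 25%.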

Compound 4, a percentage reported as inhibition, at one concentration (the size of the read-out at that concentration, not a potency): 8%
Compound 4: middle estimate and measured number agree at the digits printed; the range from low to high includes it.
By their numbers in this assay, from the lowest: compounds 2, 1 and 4 (each within the scatter of the next); then compound 3.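

In this assay this position now carries three different groups, and both a number 8 percentage points higher from compound 2 to compound 4 (within the scatter) and a number 2 percentage points higher from compound 1 to compound 4 (within the scatter) stay within the scatter, as the earlier step did. Amino, bromo and fluoro on this aromatic carbon, ortho to a large group, therefore give numbers that cannot be told apart. The exchange of amino for fluoro also takes away the hydrogen-bond donor and acceptor counted for amino without a step beyond the scatter, and no measurement at hand offers an explanation for this flat result.

A methoxy, a hydroxyl or a carboxylic acid group on this same carbon would test whether the flat result extends beyond these three groups. In this assay, among the compounds shown here, compound 3 gives 53%, but no single-change step links it to the other compounds, so the series does not yet tie that number to the identity of its chloro group or to where that group sits.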